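Aryl variation on the shared core: compound 3

This account rests on a few compounds, and the source may have more. Where it says the series, first, only, none or still open, it means among the compounds named here.

Compound 1 `CC(C)(C)Cc1c(-c2ccccn2)sc(N)c1C(=O)c1ccc(Cl)cc1` gives 1% in an assay on CHO cells for displacement of a labelled ligand from adenosine receptor A1 (Homo sapiens), read by scintillation counting, tested at 10 uM; on this read-out lower numbers stand for less inhibition and higher numbers for more inhibition at the one concentration tested (going by the name of the read-out). Compound 2 `CC(C)(C)Cc1c(-c2cn[nH]c2)sc(N)c1C(=O)c1ccc(Cl)cc1` gives 1% in this assay. The one measured step, no change at the digits printed from compound 1 to compound 2 (within the scatter), is flat, so compound 2 stands level with compound 1 on the numbers shown, both at the bottom of the read-out. Compound 3 `CC(C)(C)Cc1c(-c2ccco2)sc(N)c1C(=O)c1ccc(Cl)cc1` is not yet measured and differs from compound 2 in one place: furan-2-yl in place of 1H-pyrazol-4-yl on an aromatic carbon. Among the compounds with values here, the only step that bears on this change is the earlier exchange of one aromatic group for another at the same place on the shared core, no change at the digits printed from compound 1 to compound 2 (within the scatter), which moved nothing beyond the scatter. The expected step is therefore a number 1 percentage points higher from compound 2 to compound 3 (within the scatter), that is, none beyond the scatter. Compound 3 is estimated at 2% in this assay, with a range from -8% to 12%.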

Compound 3, a percentage reported as inhibition, at one concentration (the size of the read-out at that concentration, not a potency): 1%
The estimate for compound 3 lay 1 percentage points above the measured number, within the range that was stated.
By their numbers in this assay, from the lowest: compounds 1, 2 and 3 (each within the scatter of the next).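

In this assay, furan-2-yl, with 0 hydrogen-bond donors, reads the same as 1H-pyrazol-4-yl, with 1 hydrogen-bond donor: no change at the digits printed from compound 2 to compound 3 (within the scatter). Against pyridin-2-yl the result is also flat, no change at the digits printed from compound 1 to compound 3 (within the scatter), so none of the three aromatic groups on this carbon next to the ring sulfur lifts the read-out beyond the scatter, and the hydrogen-bond donor count of the group here makes no visible difference. Nothing at hand offers an explanation for this flat result.

All three values lie at the bottom of the read-out, so a change that would lower the number could not be seen in these compounds. On these data alone, whether a non-aromatic group at this carbon, such as an amine or a carboxylic acid, would raise the number remains open, as does the effect of a longer chain in place of the neopentyl group.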